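Removing a methyl from an oxygen in two related compounds

A few compounds are considered here, and "the series" means these few. Any claim that something is new, unique, unknown or untested is made for them only; others in the source may bear on it.

Compound 1 `COc1cc(-c2nn(-c3cccc(NC(=O)Nc4cc(C(F)(F)F)cc(C(F)(F)F)c4)c3)cc2-c2ccncc2)ccc1Cl` and compound 2 `O=C(Nc1cccc(-n2cc(-c3ccncc3)c(-c3ccc(Cl)c(O)c3)n2)c1)Nc1cc(C(F)(F)F)cc(C(F)(F)F)c1` share one core, while compound 3 `COc1cc(-c2nn(-c3cccc(NC(=O)Nc4ccc(Cl)c(C(F)(F)F)c4)c3)cc2-c2ccncc2)ccc1Cl` rests on another; the difference between the two cores is not broken down here. In a functional assay on SN12C cells (Homo sapiens) for inhibition, read by sulforhodamine B assay, with a stated time of 48 h (a higher number here means a weaker inhibitor of growth, a lower number a stronger inhibitor of growth), compound 1 gives 3320 nM, compound 2 gives 5450 nM and compound 3 gives 9230 nM. Between compound 1 and compound 2 the change is hydrogen in place of methyl on an oxygen on an aromatic ring, and it made a 1.6-fold higher number from compound 1 to compound 2 (0.22 log units; within the scatter). Compound 4 `O=C(Nc1cccc(-n2cc(-c3ccncc3)c(-c3ccc(Cl)c(O)c3)n2)c1)Nc1ccc(Cl)c(C(F)(F)F)c1` is not yet measured; it arises from compound 3 by hydrogen in place of methyl on an oxygen on an aromatic ring, the same change at the same place. The expectation rests on that one earlier instance, a 1.6-fold higher number from compound 1 to compound 2 (0.22 log units; within the scatter), and so compound 4 is expected to take a 1.5-fold higher number from compound 3 to compound 4 (0.18 log units; within the scatter), a step of about the earlier size. The estimate for compound 4 in this assay is therefore 14000 nM, expected to fall between 6000 nM and 32000 nM.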

Compound 4, concentration for total growth inhibition: 17100 nM
For compound 4 the middle estimate is 1.2-fold (0.09 log units) below the measured one, within the range that was stated.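

In this assay, going from methoxy to hydroxy on the second core gave a 1.9-fold higher number from compound 3 to compound 4 (0.27 log units; within the scatter) and so stayed within the usual scatter of the measurement. Set beside the earlier case, the change reads alike on both cores: the same change on two cores in this assay, a 1.6-fold higher number (0.22 log units; within the scatter) from compound 1 to compound 2 and a 1.9-fold higher number (0.27 log units; within the scatter) from compound 3 to compound 4, 1.1-fold (0.05 log units) apart, within the scatter of two such steps. Going by these compounds alone, this shows that the swap carried from one core to the other without a visible difference, but with only two pairs it does not show that the swap truly alters growth inhibition, or that it would carry to any further core.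

The compounds shown leave open what a longer chain on that oxygen would give, such as an ethyl or propyl group. They also leave open what an amine in place of the hydroxy would give.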